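Compound 3 to Compound 4 in a Cytotoxicity Assay

The compounds below may be only part of what the source reports. "The series", "measured", "known", "first", "only" and "open" are said of these compounds alone.

Three compounds share a common core and differ in the group attached to it. Compound 1 `CCCCSc1nc(N)nc2c1ncn2/C=C1/CC1(CO)CO` was tested in an ADME assay on MOLT-3 cells (Homo sapiens) for cytotoxicity, with a stated time of 7 days; a higher number here means that more compound is tolerated, a lower number that less compound is tolerated. For compound 1 the result is a limit of the assay, > 20000 nM, not a number. Compound 2 `Nc1nc(NC2CCCCC2)c2ncn(/C=C3/CC3(CO)CO)c2n1` has no result in this assay: "not determined" (no result reported). Compound 3 `Nc1nc(N2CCCC2)c2ncn(/C=C3/CC3(CO)CO)c2n1` likewise has no result in this assay: "not determined" (no result reported). Compound 3 therefore stands without a number of its own; of the three values shown, one is a limit of > 20000 nM in this assay, at which 1 of the 3 values shown sits, and two are entries without a single number.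

Compound 4 `C=CCOc1nc(N)nc2c1ncn2/C=C1/CC1(CO)CO` is the new compound to be measured in this assay. It differs from compound 3 in one place (allyloxy in place of pyrrolidin-1-yl on an aromatic carbon). Among the compounds with values here, no step between two measured compounds is available to guide the size of this change. In this assay no step beyond the scatter is expected in either direction. Within the data shown here, the single measured value, for compound 1, is a limit of the assay. Compound 4 is expected to give 30000 nM, within a range of 8000 nM to 100000 nM, most likely again reported as a limit.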

Compound 4, half-maximal cytotoxic concentration: > 20000 nM
Compound 4 ended at the assay's limit; the forecaster's own chance of this, stated with the estimate: 70%; the middle value lies beyond the limit too.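

Within the data shown here, compound 1 and compound 4 both stand at a limit of the assay rather than at a number, so no step between them can be read: the limit of > 20000 nM in this assay, at which 2 of the 4 values shown sit. On these data alone, how far past that limit each compound lies in this assay, and whether allyloxy and butylsulfanyl differ at all, stays open.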